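Working notes: a new group on the sulfonyl sulfur

This account rests on a few compounds, and the source may have more. Where it says the series, first, only, none or still open, it means among the compounds named here.

For the measured compounds named here, in an ADME assay on microsomes from liver (Homo sapiens) for pharmacokinetics, read by LC-MS, with a stated time of 60 min, tested at 1 uM (a higher number here means faster removal of the compound, a lower number slower removal), three compounds have values so far. Compound 1 (`O=C(NCc1cnccn1)Nc1ccc(S(=O)(=O)c2ccccc2)cc1`) gives 5 mL/min/kg, compound 2 (`Nc1ncc(CNC(=O)Nc2ccc(S(=O)(=O)c3ccccc3)cc2)cn1`) gives 3 mL/min/kg, and compound 3 (`O=C(NCc1cccnc1)Nc1ccc(S(=O)(=O)N2CC3(COC3)C2)cc1`) gives 7 mL/min/kg. Compound 3 thus lies within the scatter of compound 1 and, on the higher side, beyond the scatter of compound 2.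

The next compound to read is compound 4 (`CC1CNCCN(S(=O)(=O)c2ccc(NC(=O)NCc3cccnc3)cc2)C1`). Its change from compound 3 is a group of 8 heavy atoms (6 carbon, 2 nitrogen; one seven-membered non-aromatic ring with 2 hetero atoms) in place of a group of 7 heavy atoms (5 carbon, 1 nitrogen, 1 oxygen; 2 four-membered non-aromatic rings with 1 hetero atom each), on a sulfonyl sulfur.

Going by the values given here, only one single-place step has been measured in this assay: a 1.7-fold lower number from compound 1 to compound 2 (0.22 log units; within the scatter), with 2-aminopyrimidin-5-yl in place of pyrazin-2-yl on a saturated chain carbon bound to an amide-type nitrogen. That step lies within the scatter, and it concerns a different place in the molecule. It therefore offers only weak guidance here. Among the compounds with values here, no measured step covers a change on a sulfonyl sulfur, so the expectation starts from compound 3 at 7 mL/min/kg and has to carry a wide range.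

The expected step is a 1.1-fold higher number from compound 3 to compound 4 (0.06 log units; within the scatter), which would not go beyond the scatter. The estimate for compound 4 is 8 mL/min/kg, with an expected range from 4 mL/min/kg to 18 mL/min/kg.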

Compound 4, clearance: 8 mL/min/kg
Beside the measured number, compound 4's estimate shows no gap at the digits printed; the measured number falls inside the stated range.
By their numbers in this assay, from the lowest: compounds 2, 1, 3 and 4 (each within the scatter of the next, the first and the last beyond it).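

In this assay, the sulfonyl sulfur whose other neighbour is an aromatic carbon now has its first measured single-place step: a 1.1-fold higher number from compound 3 to compound 4 (0.06 log units; within the scatter). The group with 2 four-membered non-aromatic rings, with 0 hydrogen-bond donors, and the group with one seven-membered non-aromatic ring with 2 hetero atoms, with 1 hydrogen-bond donor, cannot be told apart by clearance, so this position accepts a marked change of ring type and donor count without a step beyond the scatter in this pair. Nothing available explains why the step is this small.

This single pair does not show whether the outcome extends to other groups on the sulfonyl sulfur, such as a morpholine, a dimethylamino group or a piperidine carrying a carboxylic acid. It also leaves open whether the methyl group on the seven-membered ring contributes to the value in this assay, and a ring with a hydrogen on that carbon in place of the methyl would be needed to read that contribution.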